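Dienone-triazole series: furan-2-yl for 3,4,5-trimethoxyphenyl

A few compounds are considered here, and "the series" means these few. Any claim that something is new, unique, unknown or untested is made for them only; others in the source may bear on it.

Compound 1 `COc1cc(/C=C/C(=O)/C=C/c2cc(OC)c(OC)c(OC)c2)ccc1OCc1cn(CCOc2cc(=O)oc3ccccc23)nn1` is the reference of the set; in a functional assay on THP-1 cells (Homo sapiens) for inhibition, read by sulforhodamine B assay, with a stated time of 48 h, tested at 50 uM (a lower number here means less inhibition of growth, a higher number more inhibition of growth at the concentration tested), compound 1 gives 99%. Compound 2 `COc1cc(/C=C/C(=O)/C=C/c2ccco2)ccc1OCc1cn(CCOc2cc(=O)oc3ccccc23)nn1` differs from it by furan-2-yl in place of 3,4,5-trimethoxyphenyl on a double-bonded chain carbon bound to a double-bonded chain carbon. In this assay compound 2 gives 78%, and the step recorded is a number 21 percentage points lower from compound 1 to compound 2 (beyond the scatter).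

Compound 3 `COc1cc(/C=C/C(=O)/C=C/c2cc(OC)c(OC)c(OC)c2)ccc1OCc1cn(CCCCCOc2cc(=O)oc3ccccc23)nn1` carries a different core; the difference between the core of compound 3 and the core of compound 1 is not broken down here. In this assay compound 3 gives 55%, the lowest of the three numbers and beyond the scatter from both compound 2 and compound 1.

Compound 4 `COc1cc(/C=C/C(=O)/C=C/c2ccco2)ccc1OCc1cn(CCCCCOc2cc(=O)oc3ccccc23)nn1` has not yet been measured. It differs from compound 3 by furan-2-yl in place of 3,4,5-trimethoxyphenyl on a double-bonded chain carbon bound to a double-bonded chain carbon, the same change and the same place as between compound 1 and compound 2. For the measured compounds named here, the step from compound 3 to compound 4 in this assay is expected to be about a number 20 percentage points lower from compound 3 to compound 4 (beyond the scatter), resting on the single earlier instance of this change, a number 21 percentage points lower from compound 1 to compound 2 (beyond the scatter). Compound 4 is therefore estimated to give about 35% in this assay, with a likely range from 15% to 55%. One prior example is a thin basis, so the range is kept wide.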

Compound 4, percent growth inhibition at one concentration: 39%
The estimate for compound 4 lay 4 percentage points below the measured number, and the stated range covers the measured number.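

In this assay, furan-2-yl in place of 3,4,5-trimethoxyphenyl again lowers growth inhibition on the second core, with a number 16 percentage points lower from compound 3 to compound 4 (beyond the scatter). The change therefore carries across the two cores in the same direction and with a size that does not differ between them: the same change on two cores in this assay, a number 21 percentage points lower (beyond the scatter) from compound 1 to compound 2 and a number 16 percentage points lower (beyond the scatter) from compound 3 to compound 4, 5 percentage points apart, within the scatter of two such steps

This agreement rests on two pairs, both read in one cell line at one concentration, so it supports no general rule for other cores and gives no reason for the drop.

Still open, as far as these compounds go, is whether the step holds on a core with a longer chain than that of compound 3, and whether it would hold for other groups on a double-bonded chain carbon bound to a double-bonded chain carbon, such as an amine or a carboxylic acid. Also open, from the compounds shown here alone, is whether the same step would appear with another read-out or in other cell lines.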